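A few compounds are considered here, and "the series" means these few. Any claim that something is new, unique, unknown or untested is made for them only; others in the source may bear on it.

Working notes on the series. Compound 3 `CCC(C)/N=C(\C)c1c(O)c2ccccc2oc1=O` stands at the weak end of what has been measured: in an assay on isolated protein for inhibition of myosin-2 (Bos taurus), read by spectrophotometry, with a stated time of 24 min (on this read-out lower numbers stand for stronger inhibition and higher numbers for weaker inhibition), compound 3 gives only a limit, >= 100000 nM, not a number. For comparison, compound 1 `C/C(=N\CC(C)C)c1c(O)c2ccccc2oc1=O` gives 34000 nM in this assay, and compound 2 `C/C(=N\Nc1ccccc1)c1c(O)c2ccccc2oc1=O` gives 27000 nM. Both steps to compound 3 went upward, an at least 2.9-fold higher number from compound 1 to compound 3 (0.46 log units; beyond the scatter) and an at least 3.7-fold higher number from compound 2 to compound 3 (0.56 log units; beyond the scatter), with the limit of >= 100000 nM in this assay, at which 1 of the 3 values shown sits, marking the limit.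

Compound 4 `C/C(=N\CCCO)c1c(O)c2ccccc2oc1=O` carries 3-hydroxypropyl in place of sec-butyl on a double-bonded nitrogen. Compounds 1 and 2 show that an isobutyl or anilino group on that nitrogen reads well below the limit, so moving away from sec-butyl is expected to bring the number back down, roughly an at least 2.5-fold lower number from compound 3 to compound 4 (0.39 log units; beyond the scatter). Compound 4 is therefore estimated at 40000 nM in this assay, within a range of 12000 nM to 150000 nM.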

Compound 4, half-maximal inhibitory concentration: 37000 nM
Compound 4: the middle estimate sits 1.1-fold (0.03 log units) above what was measured; the measured number falls inside the stated range.
By their numbers in this assay, from the lowest: compounds 2, 1 and 4 (each within the scatter of the next). At a limit, above all of these: compound 3.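

In this assay, 3-hydroxypropyl on a double-bonded nitrogen reads clear of the limit, with an at least 2.7-fold lower number from compound 3 to compound 4 (0.43 log units; beyond the scatter), although it has the same 4 heavy atoms as sec-butyl. It also brings 1 hydrogen-bond donor and 1 hydrogen-bond acceptor, yet shows no separation from the anilino or isobutyl group: a 1.4-fold higher number from compound 2 to compound 4 (0.14 log units; within the scatter) and a 1.1-fold higher number from compound 1 to compound 4 (0.04 log units; within the scatter). Compound 3 alone remains a limit and not a number: the limit of >= 100000 nM in this assay, at which 1 of the 4 values shown sits.

From the compounds shown here alone, the full size of the step from that limit stays open. Also open, going by these compounds, is whether a longer chain, an amine or a carboxylic acid on that nitrogen would read apart from this level.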